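The source may report more compounds than this note shows. Statements on the series, on what has been measured and on what is new or still open speak of the compounds shown alone.

Measured so far: compound 1, `Nc1nc2cc(Cl)c(Cl)cc2n1Cc1ccccc1`, with 170000 nM; compound 2, `Nc1nc2cc(Cl)c(Cl)cc2n1Cc1ccc(Cl)cc1`, with 45000 nM; compound 3, `Clc1ccc(Cn2c(Br)nc3cc(Cl)c(Cl)cc32)cc1`, with > 100000 nM.

All three were tested in a functional assay on KB cells (Homo sapiens) for inhibition; on this read-out higher numbers stand for weaker inhibition and lower numbers for stronger inhibition. Compound 1 gives 170000 nM, and compound 2 gives 45000 nM. The two differ by chloro in place of hydrogen on an aromatic carbon, and the step is a 3.8-fold lower number from compound 1 to compound 2 (0.58 log units; beyond the scatter). Compound 3 reaches only a limit of this assay, > 100000 nM. Compound 3 differs from compound 2 by bromo in place of amino on an aromatic carbon, and the step is an at least 2.2-fold higher number from compound 2 to compound 3 (0.34 log units; beyond the scatter). How the core of compound 3 relates to the core of compound 1 is not broken down here.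

Compound 4, `Clc1ccc(Cn2c(Br)nc3cc(Cl)c(Cl)cc32)cc1Cl`, has not yet been measured in this assay. It differs from compound 3 by chloro in place of hydrogen on an aromatic carbon. This is the same kind of change as that from compound 1 to compound 2, but not the same: there the chloro entered para to a large group, while in compound 4 it enters ortho to a chloro group and meta to a large group.

Because compound 3 sits at the limit of > 100000 nM in this assay, at which 1 of the 3 values shown sits, its step to compound 4 can only be bounded, and the estimate for compound 4 rests on the earlier step of a 3.8-fold lower number from compound 1 to compound 2 (0.58 log units; beyond the scatter). In this assay the expected step is a number no higher from compound 3 to compound 4 (the limit leaves the size open). Compound 4 is therefore estimated at 100000 nM, expected to lie between 30000 nM and 300000 nM.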

Compound 4, half-maximal inhibitory concentration: > 100000 nM
Compound 4 was reported as a limit; the forecaster's own chance of this, stated with the estimate: 55%; the middle value lies on the limit itself.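

In this assay compound 4 gives > 100000 nM, which is a limit of the assay. Compound 3 gives > 100000 nM, also a limit, so no step can be read between compound 3 and compound 4: the limit of > 100000 nM in this assay, at which 2 of the 4 values shown sit.

The compounds shown leave open whether chloro in place of hydrogen, ortho to a chloro group and meta to a large group, changes inhibition at all in compounds carrying bromo in place of amino.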